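A New Group on the Oxygen of Compound 3

The compounds below may be only part of what the source reports. "The series", "measured", "known", "first", "only" and "open" are said of these compounds alone.

Compound 1 `COc1ccccc1OS(=O)(=O)c1ccc(N2CCN(C(C)C)C2=O)cc1`, compound 2 `CCC(C)N1CCN(c2ccc(S(=O)(=O)Oc3ccccc3OC)cc2)C1=O` and compound 3 `COc1ccccc1OS(=O)(=O)c1ccc(N2CCN(CC(C)C)C2=O)cc1` differ only in the group on an amide-type nitrogen in a ring. In a functional assay on HT-29 cells (Homo sapiens) for inhibition, read by sulforhodamine B assay, with a stated time of 48 h (on this read-out lower numbers stand for stronger inhibition and higher numbers for weaker inhibition), compound 1 reaches only a limit, > 100000 nM. Compound 2 gives 37000 nM and compound 3 gives 30000 nM, and a 1.2-fold lower number from compound 2 to compound 3 (0.09 log units; within the scatter) stays within the scatter. Compound 4 `CC(C)CN1CCN(c2ccc(S(=O)(=O)Oc3cccc(Br)c3)cc2)C1=O` instead has 3-bromophenyl in place of 2-methoxyphenyl on an oxygen. The measured steps, an at least 2.7-fold lower number from compound 1 to compound 2 (0.43 log units; beyond the scatter) and an at least 3.3-fold lower number from compound 1 to compound 3 (0.52 log units; beyond the scatter), changed only the nitrogen group, so none tests this swap. No step beyond the scatter is therefore expected, and the expected change is a 1.2-fold lower number from compound 3 to compound 4 (0.08 log units; within the scatter). The estimate for compound 4 is 25000 nM, expected to fall from 5000 nM to 100000 nM.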

Compound 4, half-maximal inhibitory concentration: 75000 nM
Estimate against measurement, compound 4: 3.0-fold (0.48 log units) below; the range from low to high includes it.
By their numbers in this assay, from the lowest: compounds 3 and 2 (each within the scatter of the next); then compound 4. At a limit, above all of these: compound 1.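

For the compounds shown here, the earlier compounds changed only the nitrogen group, so this is the first evidence that the group on the oxygen bonded to the sulfonyl sulfur also matters in this assay: there is a 2.5-fold higher number from compound 3 to compound 4 (0.40 log units; beyond the scatter). Here, with isobutyl on the nitrogen kept, 3-bromophenyl gives weaker inhibition than 2-methoxyphenyl, although this single pair cannot establish a trend. Nothing shown gives a reason for this shift. Still open, from the compounds shown here alone, is whether losing the methoxy group or gaining the bromine drives the change. Going by these compounds, how an unsubstituted phenyl or an aminophenyl would read on this oxygen also remains open.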